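Adding tert-butyl to the benzamide of compound 1

The source may hold more compounds than are shown below. What is called first, only, known or untested is meant among the compounds shown, and "the series" means these compounds.

Measured in a functional assay on Daudi cells (Homo sapiens) for antiproliferative activity; on this read-out lower numbers stand for stronger inhibition and higher numbers for weaker inhibition:
- Compound 1 `Nc1ncnc2c1c(-c1ccc(NC(=O)c3ccccc3)cc1)cn2[C@H]1CCN(C[C@@H]2CO2)C1`: 3180 nM
- Compound 2 `CC(C)(C)c1ccc(COc2ccc(-c3cn([C@H]4CCN(C[C@@H]5CO5)C4)c4ncnc(N)c34)cc2)cc1`: 6970 nM

Compound 1 holds the lower of the two numbers in this assay. Compound 3 `CC(C)(C)c1ccc(C(=O)Nc2ccc(-c3cn([C@H]4CCN(C[C@@H]5CO5)C4)c4ncnc(N)c34)cc2)cc1` differs from it by one change: tert-butyl in place of hydrogen on an aromatic carbon. This tert-butyl sits on an aromatic carbon, para to a large group, and the benzamido link stays in place. For the measured compounds named here, only one measured step bears on this change, a 2.2-fold higher number from compound 1 to compound 2 (0.34 log units; beyond the scatter), a modest one. Compound 2 also carries a tert-butyl group, but that step replaces the whole benzamido group, so the evidence is indirect. Going by the values given here, no measured step isolates tert-butyl in place of hydrogen. A modest step towards a higher number is therefore expected in this assay, and it may stay within the scatter. The estimated step is a 1.5-fold higher number from compound 1 to compound 3 (0.18 log units; within the scatter). For compound 3 the expected value is 4800 nM, with an estimated range from 1600 nM to 14000 nM.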

Compound 3, half-maximal inhibitory concentration: 5980 nM
Compound 3: the middle estimate sits 1.2-fold (0.10 log units) below what was measured, within the range that was stated.
By their numbers in this assay, from the lowest: compounds 1, 3 and 2 (each within the scatter of the next, the first and the last beyond it).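

In this assay, for the compounds shown here, tert-butyl in place of hydrogen on an aromatic carbon, para to a large group, gives a 1.9-fold higher number from compound 1 to compound 3 (0.27 log units; within the scatter) and so provides the first direct reading of this change with the benzamido link left in place. This position therefore takes the tert-butyl group with no step beyond the scatter, which the earlier replacement of the whole benzamido group in compound 2 could not show. The compounds shown offer no measured explanation for this result.

On these data alone, whether a methyl group, a methoxy group, an amine or a carboxylic acid at this same position would also stay within the scatter of compound 1 remains open. Also open, as far as these compounds go, is how a longer chain on the benzamide ring would read in this assay.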